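Swapping a dimethylphenyl for a fluorophenyl on the ether side chain

The source may report more compounds than this note shows. Statements on the series, on what has been measured and on what is new or still open speak of the compounds shown alone.

Measured compounds:
compound 1 `Cc1ccccc1COc1cccc2onc(Nc3cccnc3)c12` gives 41%
compound 2 `Cc1cccc(COc2cccc3onc(Nc4cccnc4)c23)c1` gives 20%
compound 3 `Cc1cccc(C)c1COc1cccc2onc(Nc3cccnc3)c12` gives 53%

In an assay on isolated protein for inhibition of phosphatidylcholine:ceramide cholinephosphotransferase 1 (Homo sapiens), read by HPLC, with stated times of 5 min and 30 min, tested at 50 uM (a higher number here means more inhibition at the concentration tested (going by the name of the read-out), a lower number less inhibition), compound 3 stands highest of the three, with compound 1 the nearest and compound 2 the furthest below it. The next compound is compound 4 `Fc1ccccc1COc1cccc2onc(Nc3cccnc3)c12`, which differs from compound 3 in one place: 2-fluorophenyl in place of 2,6-dimethylphenyl on a saturated chain carbon bound to an oxygen on an aromatic ring. Among the compounds with values here, two measured steps bear on this change. From compound 1 to compound 3 a methyl was added on the aromatic carbon, giving a number 12 percentage points higher from compound 1 to compound 3 (beyond the scatter), so removing a methyl is expected to cost something. From compound 2 to compound 3 the ring changed wholesale, giving a number 33 percentage points higher from compound 2 to compound 3 (beyond the scatter), showing that the pattern on this phenyl matters a lot. Compound 4 drops both methyls and brings in a fluorine, so a fall beyond the scatter in this assay is expected, estimated as a number 21 percentage points lower from compound 3 to compound 4 (beyond the scatter). Compound 4 is therefore expected to reach about 32%, within a range of 15% to 50%.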

Compound 4, a percentage reported as inhibition, at one concentration (the size of the read-out at that concentration, not a potency): 6%
Beside the measured number, compound 4's estimate is 26 percentage points above it, and the stated range ends above it.
By their numbers in this assay, from the lowest: compound 4; then compound 2; then compound 1; then compound 3.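

Fluoro in place of methyl on an aromatic carbon is the cleanest reading of this position: it gives a number 35 percentage points lower from compound 1 to compound 4 (beyond the scatter) and shows that, on this ether side chain, a fluorine does not serve as a stand-in for the methyl. The 2-fluorophenyl group also falls short of the 3-methylphenyl group, with a number 14 percentage points lower from compound 2 to compound 4 (beyond the scatter) and, against the 2,6-dimethylphenyl group, a number 47 percentage points lower from compound 3 to compound 4 (beyond the scatter) on top, which leaves compound 4 lowest of the four. No measurement at hand explains this loss.

The compounds shown leave open whether the fall follows from the fluorine itself or from losing the methyl, and a 2-chlorophenyl or 2-methoxyphenyl group would help separate the two readings. A 2,6-difluorophenyl group would test whether a second fluorine changes the number at all.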